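The source may hold more compounds than are shown below. What is called first, only, known or untested is meant among the compounds shown, and "the series" means these compounds.

Measured compounds in a functional assay on NCI-H460 cells (Homo sapiens) for antiproliferative activity, read by XTT assay, with a stated time of 72 h; on this read-out lower numbers stand for stronger inhibition and higher numbers for weaker inhibition:
- compound 1 `COc1ccc(-c2cc3ccccc3nc2/C=C/C(=O)c2ccc(O)cc2)cc1`: 6930 nM
- compound 2 `COc1ccc(-c2cc3ccccc3nc2/C=C/C(=O)c2cccs2)cc1`: 5440 nM
- compound 3 `COc1ccc(-c2cc3ccccc3nc2/C=C/C(=O)c2sccc2N)cc1`: a limit of the assay, > 10000 nM

Compound 1 has the highest of the two numbers; its nearest neighbour is compound 2, with a 1.3-fold lower number from compound 1 to compound 2 (0.11 log units; within the scatter). Compound 3 sits at the limit of > 10000 nM in this assay, at which 1 of the 3 values shown sits, so its step from compound 1 is an at least 1.4-fold higher number from compound 1 to compound 3 (0.15 log units; that floor lies within the scatter) and is not a number.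

Compound 4 `COc1ccc(-c2cc3ccccc3nc2/C=C/C(=O)c2c[nH]c3ccccc23)cc1` differs from compound 1 by 1H-indol-3-yl in place of 4-hydroxyphenyl on a carbonyl carbon. Within the data shown here, the only comparable exchange at the carbonyl carbon, from compound 1 to compound 2, stayed within the scatter, and the other exchange ended at a limit. No step beyond the scatter is therefore expected in this assay. The step from compound 1 to compound 4 is estimated as a 1.1-fold lower number from compound 1 to compound 4 (0.03 log units; within the scatter). Compound 4 is expected at 6500 nM, between 2500 nM and 16000 nM.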

Compound 4, half-maximal inhibitory concentration: 8010 nM
Compound 4: the middle estimate sits 1.2-fold (0.09 log units) below what was measured, and the stated range covers the measured number.
By their numbers in this assay, from the lowest: compounds 2, 1 and 4 (each within the scatter of the next). At a limit, above all of these: compound 3.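

In this assay, a group with both a five-membered and a six-membered aromatic ring on the carbonyl carbon gives no step beyond the scatter: a 1.2-fold higher number from compound 1 to compound 4 (0.06 log units; within the scatter), and a 1.5-fold higher number from compound 2 to compound 4 (0.17 log units; within the scatter). Compounds 1, 2 and 4 thus hold three different aromatic groups at this place without a separation, while compound 3 remains at a limit, not a number: the limit of > 10000 nM in this assay, at which 1 of the 4 values shown sits. Its step, an at least 1.2-fold lower number from compound 3 to compound 4 (0.09 log units; that floor lies within the scatter), sets no order.

On these data alone, it remains open whether an open-chain amine or a phenyl ring bearing a carboxylic acid at this carbonyl carbon would move the number beyond the scatter.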